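The compounds below may be only part of what the source reports. "The series", "measured", "known", "first", "only" and "open" are said of these compounds alone.

In a functional assay on MCF7 cells (Homo sapiens) for antiproliferative activity, read by MTT assay, with a stated time of 48 h (on this read-out higher numbers stand for weaker inhibition and lower numbers for stronger inhibition), compound 1 `COc1ccc(/C=C/C=C\c2cc(OC)c(OC)c(OC)c2)cc1O` gives 75 nM. Compound 2 `CCOc1cc(-c2ccc3cc[nH]c3c2)cn2c(-c3cc(OC)c(OC)c(OC)c3)nnc12` gives 334 nM in this assay; of the two numbers shown, compound 2 stands highest, and its gap to compound 1 is beyond the scatter. Compound 3 `CCOc1cc(-c2ccc3c(ccn3C)c2)cn2c(-c3cc(OC)c(OC)c(OC)c3)nnc12` carries 1-methyl-1H-indol-5-yl in place of 1H-indol-6-yl on an aromatic carbon. Within the data shown here, no step between measured compounds covers this change, so compound 1 and compound 2 alone give no size for it. The expected step is a 1.2-fold higher number from compound 2 to compound 3 (0.08 log units; within the scatter), if anything toward a somewhat higher number. For compound 3 the expected value in this assay is 400 nM, with a range from 120 nM to 1300 nM.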

Compound 3, half-maximal inhibitory concentration: 140 nM
Compound 3: middle estimate off by 2.9-fold (0.46 log units), on the high side; the measured number falls inside the stated range.
By their numbers in this assay, from the lowest: compounds 1 and 3 (each within the scatter of the next); then compound 2.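

In this assay, 1-methyl-1H-indol-5-yl in place of 1H-indol-6-yl gives a 2.4-fold lower number from compound 2 to compound 3 (0.38 log units; beyond the scatter), so the number at this aromatic carbon responds to the indole group it carries. The step joins two changes, the methyl on the indole nitrogen and the moved point of attachment, and this single pair cannot separate them. No measurement on hand offers an explanation for the step.

Open, from the compounds shown here alone, is how 1H-indol-5-yl and 1-methyl-1H-indol-6-yl would read, as these would part the two changes. Also open, going by these compounds, is whether an ethyl on the indole nitrogen would move the number further.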